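Adding a Third Methoxy Group to a Styryl Lactone

The source may hold more compounds than are shown below. What is called first, only, known or untested is meant among the compounds shown, and "the series" means these compounds.

Measured compounds:
compound 1 `COc1ccc(/C=C/c2cc(=O)cco2)cc1OC` — 954 uM
compound 2 `COc1ccc(/C=C/C2CC=CC(=O)O2)cc1` — 25.5 uM
compound 3 `COc1ccc(/C=C/C2CC=CC(=O)O2)c(OC)c1` — 5.4 uM

In a functional assay on MCF7 cells (Homo sapiens) for inhibition, read by sulforhodamine B assay, with a stated time of 48 h (a lower number here means a stronger inhibitor of growth, a higher number a weaker inhibitor of growth), compound 3 gives the lowest number of the three, and compound 2 is the nearest to it, while compound 1 stands far away with a much higher number. Compound 4 `COc1cc(OC)c(OC)cc1/C=C/C1CC=CC(=O)O1` differs from compound 3 in one place: methoxy in place of hydrogen on an aromatic carbon.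

Among the compounds with values here, only one measured step bears on this change. The step of a 4.7-fold lower number from compound 2 to compound 3 (0.67 log units; beyond the scatter) shows that adding a methoxy group to the aromatic ring of the shared core lowered the number to a modest degree. Within the data shown here, compound 4 repeats the same kind of change on compound 3, so a further lowering of similar or smaller size is expected in this assay, though no measured pair shows this third methoxy group itself, and a step within the scatter cannot be ruled out.

On that basis compound 4 is estimated at 3 uM, with a range from 0.8 uM to 12 uM, which means an expected step of a 1.8-fold lower number from compound 3 to compound 4 (0.26 log units; within the scatter).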

Compound 4, concentration for growth inhibition (reported as GI): 3.8 uM
Compound 4: middle estimate off by 1.3-fold (0.10 log units), on the low side, within the range that was stated.
By their numbers in this assay, from the lowest: compounds 4 and 3 (each within the scatter of the next); then compound 2; then compound 1.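

In this assay, the methoxy group entering on the aromatic carbon ortho to a methoxy group and para to a methoxy group gives a 1.4-fold lower number from compound 3 to compound 4 (0.15 log units; within the scatter) and so, unlike a 4.7-fold lower number from compound 2 to compound 3 (0.67 log units; beyond the scatter) on the earlier pair, stays within the scatter. At this position, then, the change from hydrogen to methoxy leaves compound 3 and compound 4 indistinguishable in this assay, so the step seen on the earlier pair does not carry over as a clear further gain. No measurement offered here accounts for this result.

The compounds shown carry only hydrogen or methoxy at this position, so they leave open how an amine, a hydroxyl group or a longer chain such as butoxy would read there. They also leave open whether compound 4 would keep this standing with any other group on the same carbon.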